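The compounds below may be only part of what the source reports. "The series", "measured", "known", "first", "only" and "open" are said of these compounds alone.

In an ADME assay on the whole organism (strain FVB) for pharmacokinetics, with Mus musculus as the target, read by LC-MS, at a dose of 30 mg/kg by the oral route (on this read-out higher numbers stand for higher exposure at the dose given and lower numbers for lower exposure), compound 1 `c1cc([C@H]2CC[C@]3(CC2)OOC2(O3)C3CC4CC(C3)CC2C4)ccc1OC1CCNCC1` gives 810 nM, compound 2 `c1cc([C@H]2CC[C@]3(CC2)OOC2(O3)C3CC4CC(C3)CC2C4)ccc1OCC1CCNCC1` gives 465 nM and compound 3 `NCCCCOc1ccc([C@H]2CC[C@]3(CC2)OOC2(O3)C3CC4CC(C3)CC2C4)cc1` gives 370 nM. Compound 3 stands clearly apart from compound 1 only. The data show a 2.2-fold lower number from compound 1 to compound 3 (0.34 log units; beyond the scatter) and a 1.3-fold lower number from compound 2 to compound 3 (0.10 log units; within the scatter). Compound 4 `CC1(C)CC(O)(COc2ccc([C@H]3CC[C@]4(CC3)OOC3(O4)C4CC5CC(C4)CC3C5)cc2)CC(C)(C)N1` keeps the shared core but changes the side chain: 4-hydroxy-2,2,6,6-tetramethylpiperidin-4-yl in place of 3-aminopropyl on a saturated chain carbon bound to an oxygen on an aromatic ring. Here 4-hydroxy-2,2,6,6-tetramethylpiperidin-4-yl takes the place of 3-aminopropyl, and no measured compound carries this group. The closest guides are the side-chain changes already measured: a 2.2-fold lower number from compound 1 to compound 3 (0.34 log units; beyond the scatter) was modest and a 1.7-fold lower number from compound 1 to compound 2 (0.24 log units; within the scatter) stayed small. No step beyond the scatter is therefore expected in this assay. The expected step is a 1.3-fold higher number from compound 3 to compound 4 (0.11 log units; within the scatter). The estimate for compound 4 is 480 nM, with a range of 170 nM to 1300 nM.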

Compound 4, maximal plasma concentration: 1000 nM
The estimate for compound 4 lay 2.1-fold (0.32 log units) below the measured number, and the stated range covers the measured number.
By their numbers in this assay, from the lowest: compounds 3, 2, 1 and 4 (each within the scatter of the next, the first and the last beyond it).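

In this assay, a far larger side chain holds up at this place, on a saturated chain carbon bound to an oxygen on an aromatic ring: the change gives a 2.7-fold higher number from compound 3 to compound 4 (0.43 log units; beyond the scatter) and a 2.2-fold higher number from compound 2 to compound 4 (0.33 log units; beyond the scatter). Set against the shorter link to piperidin-4-yl, it gives a 1.2-fold higher number from compound 1 to compound 4 (0.09 log units; within the scatter), so the two stay level. No measurement shown explains the rise. Still open, on these data alone, is whether the hydroxy group alone or the methyl groups alone would give the same result. A morpholine ring or a carboxylic acid on this chain also remains untested among the compounds shown.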